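The compounds below may be only part of what the source reports. "The series", "measured", "known", "first", "only" and "open" are said of these compounds alone.

Compound 1, `O=C(Nc1cccc(-n2cc(-c3ccncc3)c(-c3cc(O)cc(Cl)c3)n2)c1)Nc1ccc(Cl)c(Cl)c1`: 90%
Compound 2, `COc1cc(Cl)cc(-c2nn(-c3cccc(NC(=O)Nc4cc(C(F)(F)F)cc(C(F)(F)F)c4)c3)cc2-c2ccncc2)c1`: 48%

Of the compounds shown here, two have so far been measured in a functional assay on NCI/ADR-RES cells (Homo sapiens) for inhibition, read by sulforhodamine B assay, with a stated time of 48 h, tested at 1 uM; on this read-out higher numbers stand for a weaker effect at the one concentration tested and lower numbers for a stronger effect. Compound 1 gives 90%, the higher of the two numbers and thus the weaker effect at the concentration tested. Compound 2 gives 48%, a number beyond the usual scatter below that of compound 1. The two differ in more than one place, so nothing can be read from them about any single change.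

Compound 3, `COc1cc(Cl)cc(-c2nn(-c3cccc(NC(=O)Nc4ccc(Cl)c(Cl)c4)c3)cc2-c2ccncc2)c1`, has not yet been measured. It differs from compound 1 in one place: methyl in place of hydrogen on an oxygen on an aromatic ring. Going by the values given here, no measured pair shows this change alone, so its size is not known from the numbers. Because compound 2, which also carries a methoxy group, gives 48%, a moderate downward step a number 18 percentage points lower from compound 1 to compound 3 (beyond the scatter) is expected, although a step within the scatter is also possible. Compound 3 is expected to give about 72%, between 45% and 95%.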

Compound 3, a percentage reported as activity, at one concentration (the size of the read-out at that concentration, not a potency): 78%
Compound 3: the middle estimate sits 6 percentage points below what was measured, within the range that was stated.
By their numbers in this assay, from the lowest: compound 2; then compound 3; then compound 1.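

Replacing hydroxy with methoxy, which turns the 3-chloro-5-hydroxyphenyl group into 3-chloro-5-methoxyphenyl while the rest of the molecule stays the same, gives a number 12 percentage points lower from compound 1 to compound 3 (beyond the scatter) in this assay. Going by these compounds alone, this is the first direct measure of this change alone: a lower number here means a stronger effect, so putting methyl on this oxygen does not weaken the effect at the concentration tested, but modestly strengthens it. Nothing available explains why the number moves in this direction.

The compounds shown include only hydrogen and methyl on this oxygen, so it remains open whether an ethyl group or a longer chain would continue the trend, or whether one ending in an amine or a carboxylic acid would reverse it. With a single concentration and a single cell line, the step also says nothing about potency or about how the effect would look in other cells.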